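Removing a methoxy group from a bromophenyl triazine

A few compounds are considered here, and "the series" means these few. Any claim that something is new, unique, unknown or untested is made for them only; others in the source may bear on it.

Three compounds share a diamino-triazine core carrying a substituted phenyl ring. In a functional assay on the whole organism with Rattus norvegicus as the target, at a dose of 20 mg/kg by the intraperitoneal route (on this read-out higher numbers stand for more inhibition at the one dose given (going by the name of the read-out) and lower numbers for less inhibition), compound 1 `Nc1nc(N)nc(-c2ccccc2Br)n1` gives 26%, compound 2 `COc1ccc(Br)cc1-c1nc(N)nc(N)n1` gives 49%, and compound 3 `Nc1nc(N)nc(-c2cc(F)ccc2Cl)n1` gives 78%. Compound 2 therefore stands second highest of the three, lying beyond the scatter from both neighbours. The unmeasured compound 4 `Nc1nc(N)nc(-c2cccc(Br)c2)n1` differs from compound 2 by one change (hydrogen in place of methoxy on an aromatic carbon), a small group removed and nothing added in its place. Within the data shown here, with no measured pair of this kind to lean on, the expected step is a loss of inhibition, probably beyond the scatter, since the remaining bromophenyl pattern resembles the weaker end of the set. The expected step of a number 15 percentage points lower from compound 2 to compound 4 (beyond the scatter) is a decrease. For compound 4 the estimated value is 34%, with a range from 10% to 62%.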

Compound 4, a percentage reported as inhibition, in the whole organism at one dose (the size of the read-out at that dose, not a potency): 96%
Compound 4: middle estimate off by 62 percentage points, on the low side, outside the stated range (above it).
By their numbers in this assay, from the lowest: compound 1; then compound 2; then compound 3; then compound 4.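

The change at this position, ortho to a group of 8 heavy atoms and para to a bromo group, gives a large step, a number 47 percentage points higher from compound 2 to compound 4 (beyond the scatter) in this assay at its one dose. Among these compounds, this is the first comparison here in which only one place differs, and it shows that inhibition does not depend on the methoxy group. Nothing measured here accounts for the size of this step.

Still open, from the compounds shown here alone, is how an amine, a hydroxyl group or a longer chain such as ethoxy would fare at this position. Also open, going by these compounds, is whether the bromo group could be exchanged for a chloro group without altering the result.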